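A Cyanophenyl Swap on a Core That Shows Only Limits

A few compounds are considered here, and "the series" means these few. Any claim that something is new, unique, unknown or untested is made for them only; others in the source may bear on it.

Compound 1 `O=C(Nc1ccc(Cl)cc1)N1CCC[C@H]1c1nc(-c2ccccc2F)no1` stands at a limit in an ADME assay on MCF-10A cells (Homo sapiens) for inhibition, with a stated time of 48 h (a lower number here means a stronger inhibitor, a higher number a weaker inhibitor), giving > 50000 nM. Compound 2 `O=C(Nc1ccc(Cl)cc1)N1CCC[C@H]1c1nc(-c2cccc(Cl)c2)no1` also stands at a limit, giving > 50000 nM in this assay. Among the measured compounds shown here, the one measured step, a step that the two limits leave unreadable from compound 1 to compound 2, therefore cannot be read, and the limit of > 50000 nM in this assay, at which 2 of the 2 values shown sit, is the whole of the evidence on hand. Compound 3 `N#Cc1ccc(-c2noc([C@@H]3CCCN3C(=O)Nc3ccc(Cl)cc3)n2)cc1` differs from compound 1 by 4-cyanophenyl in place of 2-fluorophenyl on an aromatic carbon. With no readable step anywhere in this set, no change beyond the scatter is expected, and compound 3 is expected to sit at the limit as well, with an estimate of 50000 nM spanning 25000 nM to 100000 nM, an expected step of a number no higher from compound 1 to compound 3 (the limit leaves the size open).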

Compound 3, half-maximal inhibitory concentration: > 50000 nM
Compound 3: only a limit was reported; the forecaster's own chance of this, stated with the estimate: 85%; the middle value lies on the limit itself.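

Among the compounds shown here, compound 3 also stands at a limit, so no step among compound 1, compound 2 and compound 3 can be read. The compounds shown leave open how strongly any of them inhibits in this assay, and the evidence stops at one point: the limit of > 50000 nM in this assay, at which 3 of the 3 values shown sit.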